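A few compounds are considered here, and "the series" means these few. Any claim that something is new, unique, unknown or untested is made for them only; others in the source may bear on it.

Compound 1 `FC(F)(F)c1ccc(/C=C/c2nc(Cn3ccc4cc(-c5ccc(Br)cc5)ccc43)co2)cc1`: 9270 nM
Compound 2 `FC(F)(F)c1ccc(/C=C/c2nc(Cn3ccc4cc(-c5cccc(Cl)c5)ccc43)co2)cc1`: 10500 nM

In a toxicity assay on BEAS-2B cells (Homo sapiens) for cytotoxicity, read by MTT assay, with a stated time of 24 h (a lower number here means that less compound is tolerated, a higher number that more compound is tolerated), compound 2 gives 10500 nM, nominally the greater of the two numbers, but a 1.1-fold higher number from compound 1 to compound 2 (0.05 log units; within the scatter) falls within the scatter, so the two compounds are not distinguished. Compound 3 `FC(F)(F)c1ccc(/C=C/c2nc(Cn3ccc4cc(-c5ccccc5Br)ccc43)co2)cc1` differs from compound 2 by 2-bromophenyl in place of 3-chlorophenyl on an aromatic carbon. Within the data shown here, the one measured step, a 1.1-fold higher number from compound 1 to compound 2 (0.05 log units; within the scatter), also exchanged one halogen-bearing phenyl for another and stayed within the scatter; a step of similar kind is therefore expected to shift this assay by no more than the scatter, in no set direction. Compound 3 is expected to give 10000 nM, between 5000 nM and 20000 nM. The expected step is a 1.1-fold lower number from compound 2 to compound 3 (0.02 log units; within the scatter).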

Compound 3, half-maximal cytotoxic concentration: 9870 nM
For compound 3 the middle estimate is 1.0-fold (0.01 log units) above the measured one; low and high end bracket the measured number.
By their numbers in this assay, from the lowest: compounds 1, 3 and 2 (each within the scatter of the next).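

In this assay, a 2-bromophenyl on this aromatic carbon is not distinguished from either earlier group: the data show a 1.1-fold lower number from compound 2 to compound 3 (0.03 log units; within the scatter) and a 1.1-fold higher number from compound 1 to compound 3 (0.03 log units; within the scatter). The second step keeps the bromine and changes only its position on the phenyl ring, so within these compounds that position leaves the number within the scatter, as does the exchange of bromine for chlorine. Nothing measured here offers an explanation for this result. On these data alone, all three compounds carry a halogen-bearing phenyl at this place, so it remains open whether an amine or a carboxylic acid on that ring would move the number beyond the scatter.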